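This account rests on a few compounds, and the source may have more. Where it says the series, first, only, none or still open, it means among the compounds named here.

Compound 1 `C=C1[C@@H](OC(C)=O)C[C@@H]2[C@](C)(CO[Si](C)(C)C(C)(C)C)[C@H](OC(C)=O)CC[C@@]2(C)[C@@H]1C[C@@H](Nc1ccc(OC)c(OC)c1)C1=CCOC1=O` is the reference point. Among the compounds with values here, in a functional assay on MCF7 cells (Homo sapiens) for cytotoxicity, read by sulforhodamine B assay (on this read-out higher numbers stand for weaker inhibition and lower numbers for stronger inhibition), compound 1 gives 4310 nM, which is the only definite number among the two measured compounds. Compound 2 `C=C1[C@@H](OC(C)=O)C[C@@H]2[C@](C)(COC=O)[C@H](OC(C)=O)CC[C@@]2(C)[C@@H]1C[C@@H](Nc1ccc(OC)c(OC)c1)C1=CCOC1=O` differs from compound 1 only at an oxygen on a saturated carbon, far from the aromatic ring. For compound 2 this assay reports only a limit, > 50000 nM. That limit is the limit of > 50000 nM in this assay, at which 1 of the 2 values shown sits. The step recorded there is an at least 11-fold higher number from compound 1 to compound 2 (1.06 log units; beyond the scatter).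

Compound 3 `C=C1[C@@H](OC(C)=O)C[C@@H]2[C@](C)(CO[Si](C)(C)C(C)(C)C)[C@H](OC(C)=O)CC[C@@]2(C)[C@@H]1C[C@@H](Nc1cccc(OC)c1)C1=CCOC1=O` is still to be tested. Its difference from compound 1 is hydrogen in place of methoxy on an aromatic carbon. Within the data shown here, the single measured step concerns a group on the saturated part of the core, not the aromatic amine, so no measured step bears on this change, and the data give no guide for what removing a methoxy from the aromatic ring does. Without such guidance the change is expected to stay within the usual scatter, in no particular direction, so the step of a 1.3-fold higher number from compound 1 to compound 3 (0.11 log units; within the scatter) is what is estimated. Compound 3 is therefore expected to give about 5500 nM in this assay, with a range from 1800 nM to 20000 nM.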

Compound 3, half-maximal inhibitory concentration: 28100 nM
Compound 3: middle estimate off by 5.1-fold (0.71 log units), on the low side; measured number above the stated range.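

The aromatic ring is not a silent part of these molecules: in this assay, changing 3,4-dimethoxyphenyl to 3-methoxyphenyl gives a 6.5-fold higher number from compound 1 to compound 3 (0.81 log units; beyond the scatter). Since a higher number here means weaker inhibition, the methoxy group that sits ortho to the remaining methoxy and para to a large group contributes to the measured cytotoxicity of compound 1, and the earlier comparison, made on an oxygen on a saturated carbon, could not show this. Nothing in the data shown explains why losing this one group weakens the effect.

On these data alone, whether another group in the same place, such as a hydroxyl, a fluorine or an amine, would restore the value of compound 1 remains open. As far as these compounds go, it is also open whether the remaining methoxy matters as much, and whether this step would keep its size with a different group on the saturated part of the shared core.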